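The compounds below may be only part of what the source reports. "The series", "measured", "known", "first", "only" and "open" are said of these compounds alone.

Working notes on the series, read in a functional assay on A-375 cells (Homo sapiens) for antiproliferative activity (on this read-out higher numbers stand for weaker inhibition and lower numbers for stronger inhibition), throughout. Among the compounds with values here, compound 1 (`O=C(Nc1ccc(-c2cscn2)cc1)C1CCCN(Cc2ccc(F)c(F)c2)C1`) gives 880 nM here, and compound 2 (`O=C(Nc1ccc(-c2cscn2)cc1)C1CCCN(Cc2cc(F)c(F)c(F)c2)C1`) gives 400 nM and holds the lower of the two numbers so far, the stronger inhibition of the pair. Compound 3 (`O=C(Nc1ccc(-c2cscn2)cc1)C1CCCN(Cc2cccc(C(F)(F)F)c2)C1`) is not yet measured. Its change from compound 2 (3-(trifluoromethyl)phenyl in place of 3,4,5-trifluorophenyl on a saturated chain carbon bound to an amine nitrogen in a ring) places 3-(trifluoromethyl)phenyl in place of 3,4,5-trifluorophenyl on a saturated chain carbon bound to an amine nitrogen in a ring.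

Within the data shown here, only one measured step bears on this, namely a 2.2-fold lower number from compound 1 to compound 2 (0.34 log units; beyond the scatter) for fluoro in place of hydrogen on an aromatic carbon, and that step is modest. Among the measured compounds shown here, it is an indirect guide, as no measured compound carries trifluoromethyl. A small move back toward the higher number of compound 1 is the most that can be read from it, and the direction is uncertain. The estimated step is a 1.5-fold higher number from compound 2 to compound 3 (0.18 log units; within the scatter) and is expected to lean toward a higher number without clearly passing the scatter. For compound 3 the expected value is 600 nM with an estimated range from 220 nM to 1600 nM in this assay read-out.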

Compound 3, half-maximal inhibitory concentration: > 20000 nM
Compound 3 was reported as a limit (the forecaster's own chance of this, stated with the estimate: 3%); middle value at least 33-fold (1.52 log units) from the limit.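

In this assay compound 3 is reported only as a limit, not as a number: the limit of > 20000 nM in this assay, at which 1 of the 3 values shown sits. Within the data shown here, on a saturated chain carbon bound to an amine nitrogen in a ring, the earlier compounds showed only a modest response, a 2.2-fold lower number from compound 1 to compound 2 (0.34 log units; beyond the scatter), whereas replacing the fluorinated phenyl with 3-(trifluoromethyl)phenyl gives far larger steps: an at least 50-fold higher number from compound 2 to compound 3 (1.69 log units; beyond the scatter), and an at least 22-fold higher number from compound 1 to compound 3 (1.35 log units; beyond the scatter). The group that leaves in the first of these larger steps and the group that enters carry the same count of fluorine, and the heavy-atom counts printed for them lie close together, so among these compounds neither the presence of fluorine nor its count decides the read-out at this position.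

The compounds shown cannot separate the effect of the trifluoromethyl group itself from the effect of having no fluoro on the ring carbons that carry it in compound 1 and compound 2. From the compounds shown here alone, a plain phenyl, a 3-fluorophenyl, a 3-chlorophenyl or a 3-methylphenyl at this position would be needed to tell these apart, and whether any group of that kind keeps the inhibition remains open.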